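The compounds below may be only part of what the source reports. "The series", "measured", "known", "first", "only" and "open" are said of these compounds alone.

Measured compounds:

- Compound 1, `COc1ccc(/C=C2\CN(C)C/C(=C\c3ccc(OC)c(OC)c3)C2=O)cc1OC`: in a functional assay on NCI-H1650 cells (Homo sapiens) for cytotoxicity, read by MTT assay, with a stated time of 72 h (on this read-out lower numbers stand for stronger inhibition and higher numbers for weaker inhibition), compound 1 gives 9000 nM.
- Compound 2, `CCN1C/C(=C\c2ccc(OC)c(OC)c2)C(=O)/C(=C/c2ccc(OC)c(OC)c2)C1`: in this assay compound 2 gives 12000 nM.
- Compound 3, `COc1cc(/C=C2\CN(C(=O)C(C)C)C/C(=C\c3cc(OC)c(OC)c(OC)c3)C2=O)cc(OC)c1OC`: in this assay compound 3 gives 10800 nM.

The three measured compounds sit close together in this assay, and none of the gaps among them reaches beyond the usual scatter. Compound 2 and compound 1 differ in one place, (hydrogen in place of methyl on a saturated chain carbon bound to an amine nitrogen in a ring), and this change made a 1.3-fold lower number from compound 2 to compound 1 (0.12 log units; within the scatter). Compound 3 has a different core from compound 2; the difference between the two cores is not broken down here.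

The unmeasured compound 4, `CCC(=O)N1C/C(=C\c2cc(OC)c(OC)c(OC)c2)C(=O)/C(=C/c2cc(OC)c(OC)c(OC)c2)C1`, differs from compound 3 in one place: hydrogen in place of methyl on a saturated chain carbon bound to a carbonyl carbon and a saturated chain carbon. Among the compounds with values here, this is the same kind of change as the one from compound 2 to compound 1, a methyl giving way to a hydrogen, but the place is not the same: in the earlier pair the carbon carrying the change is bound to an amine nitrogen in a ring, whereas here it is bound to a carbonyl carbon and a saturated chain carbon. Because the earlier step was a 1.3-fold lower number from compound 2 to compound 1 (0.12 log units; within the scatter), and because compound 3 gives 10800 nM, the step from compound 3 to compound 4 in this assay is expected to be small, around a 1.1-fold lower number from compound 3 to compound 4 (0.06 log units; within the scatter). Compound 4 is estimated to give 9500 nM in this assay, most likely between 4000 nM and 25000 nM.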

Compound 4, half-maximal inhibitory concentration: 4400 nM
For compound 4 the middle estimate is 2.2-fold (0.33 log units) above the measured one; measured number inside the range.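

Shortening isopropylcarbonyl to propanoyl, with a hydrogen in place of a methyl on a saturated chain carbon bound to a carbonyl carbon and a saturated chain carbon, gives a 2.5-fold lower number from compound 3 to compound 4 (0.39 log units; beyond the scatter) in this assay, a modest step. Set beside the earlier step, the two results do not differ by more than two such steps can be expected to scatter: the same change on two cores in this assay, a 1.3-fold lower number (0.12 log units; within the scatter) from compound 2 to compound 1 and a 2.5-fold lower number (0.39 log units; beyond the scatter) from compound 3 to compound 4, 1.8-fold (0.27 log units) apart, within the scatter of two such steps. Within the data shown here, this shows no sign that the change behaves differently on the two cores, but it does not show that the change carries over with a fixed size, since there is only one pair on each core, the earlier step lies within the scatter on its own, and the carbon carrying the change is bound to different atoms in the two pairs.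

On these data alone, it remains open whether an acetyl group or a longer butanoyl chain in place of the propanoyl group would move the number further in the same direction, or whether the step seen here is a single case. As far as these compounds go, it is also open what an amine or a carboxylic acid at the end of that chain would do in this assay.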